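The source may report more compounds than this note shows. Statements on the series, on what has been measured and on what is new or still open speak of the compounds shown alone.

Of the compounds shown here, three of one shared core have been tested in a functional assay (cardiac atrium) for agonist activity, with Cavia porcellus as the target; on this read-out higher numbers stand for an effect only at larger amounts of compound and lower numbers for an effect already at smaller amounts. Compound 1 `CCO/C(O)=C1\C(C)=NC(C)=C([N+](=O)[O-])C1c1ccncc1` gives 6460 nM in this assay. Compound 2 `CC1=NC(C)=C([N+](=O)[O-])C(c2cccnc2)/C1=C(\O)OC(C)C` gives 28500 nM in this assay. Compound 3 `CC1=NC(C)=C([N+](=O)[O-])C(c2ccccn2)/C1=C(\O)OC(C)(C)C` gives 1810000 nM in this assay. On these three numbers compound 2 stands second highest: its nearest neighbour is compound 1, whose number is lower by more than the usual scatter, and its furthest is compound 3, whose number is higher by far more than the scatter. None of these pairs differs in only one place, so no single step can be read off directly.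

Compound 4 `CC1=NC(C)=C([N+](=O)[O-])C(c2cccnc2)/C1=C(\O)OCC(C)C` has not yet been measured in this assay. It differs from compound 2 in one place: isobutyl in place of isopropyl on an oxygen on an unsaturated carbon. Going by the values given here, the change adds a single carbon to the chain on the oxygen on the unsaturated carbon, and nothing among the measured compounds isolates the effect of such a change. Among the compounds with values here, with no step to lean on, the expectation for compound 4 is a modest step in this assay, a 1.1-fold higher number from compound 2 to compound 4 (0.05 log units; within the scatter), close to the scatter of the method. The estimate for compound 4 is therefore 32000 nM, with a range from 8000 nM to 130000 nM.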

Compound 4, half-maximal effective concentration: 1740 nM
Compound 4: the middle estimate sits 18-fold (1.26 log units) above what was measured; measured number outside the range, below it.
By their numbers in this assay, from the lowest: compound 4; then compound 1; then compound 2; then compound 3.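

In this assay, putting isobutyl in place of isopropyl on the oxygen on the unsaturated carbon gives a 16-fold lower number from compound 2 to compound 4 (1.21 log units; beyond the scatter), a large move for a change of a single carbon in the chain. The earlier compounds shown here differed in more than one place and could not isolate this position, but this pair shows that the read-out responds strongly to the chain on this oxygen, and that a small change there can shift the number well beyond the usual scatter. No measurement at hand explains this step.

From the compounds shown here alone, it remains open how a longer chain such as n-pentyl, or a benzyl group, would read on this oxygen. Going by these compounds, whether the same swap would give a step of similar size on compound 1 or compound 3 also remains open.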